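The source may hold more compounds than are shown below. What is called first, only, known or untested is meant among the compounds shown, and "the series" means these compounds.

Measured compounds in an ADME assay on MT4 cells (Homo sapiens) for cytotoxicity, read by MTT assay, with a stated time of 5 days; on this read-out lower numbers stand for higher toxicity in this test and higher numbers for lower toxicity in this test:
- compound 1 `CCCCN(c1ccnc(Nc2ccc(C#N)cc2)n1)c1c(F)cc(-c2ccc(C#N)cc2)cc1F` gives 211000 nM
- compound 2 `CC(C)N(c1ccnc(Nc2ccc(C#N)cc2)n1)c1c(F)cc(-c2ccc(C#N)cc2)cc1F` gives 172000 nM
- compound 3 `CCC(C)N(c1ccnc(Nc2ccc(C#N)cc2)n1)c1c(F)cc(-c2ccc(C#N)cc2)cc1F` gives 217000 nM

All three share one core and differ only in the alkyl group on a nitrogen on an aromatic ring. Compound 3 holds the highest of the three numbers in this assay, but every step to it stays within the scatter: a 1.0-fold higher number from compound 1 to compound 3 (0.01 log units; within the scatter) and a 1.3-fold higher number from compound 2 to compound 3 (0.10 log units; within the scatter). The remaining pair behaves the same way, a 1.2-fold lower number from compound 1 to compound 2 (0.09 log units; within the scatter). So far, swapping one small alkyl group for another at this nitrogen has produced no movement that can be separated from repeat-measurement noise.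

Compound 4 `N#Cc1ccc(Nc2nccc(N(c3c(F)cc(-c4ccc(C#N)cc4)cc3F)C3CCCC3)n2)cc1` has not yet been run in this assay. It differs from compound 3 by cyclopentyl in place of sec-butyl on a nitrogen on an aromatic ring. All three measured steps bear on this change, since each also exchanges the alkyl group on that nitrogen, and none of them left the scatter. The expectation for this assay is therefore a step of no real size, in no particular direction: a 1.0-fold lower number from compound 3 to compound 4 (0.01 log units; within the scatter) is what is anticipated. Compound 4 is estimated to give 210000 nM, with a likely range from 120000 nM to 370000 nM.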

Compound 4, half-maximal cytotoxic concentration: 232000 nM
The estimate for compound 4 lay 1.1-fold (0.04 log units) below the measured number; the measured number falls inside the stated range.
By their numbers in this assay, from the lowest: compounds 2, 1, 3 and 4 (each within the scatter of the next).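

In this assay, cyclopentyl brings the first ring to this nitrogen, and the number stays within the scatter of all three open-chain compounds (a 1.1-fold higher number from compound 3 to compound 4 (0.03 log units; within the scatter); a 1.3-fold higher number from compound 2 to compound 4 (0.13 log units; within the scatter); a 1.1-fold higher number from compound 1 to compound 4 (0.04 log units; within the scatter)). Across butyl, isopropyl, sec-butyl and cyclopentyl, this read-out therefore separates neither open chains from a carbon-only five-membered ring nor the compounds with 4 or 5 heavy atoms in the group that enters or leaves here. No available evidence bears on why the number holds steady across these groups.

Still open, on these data alone, is whether a group carrying an amine or a carboxylic acid, or a longer chain such as octyl, would move the number in this assay beyond the scatter. As far as these compounds go, whether larger carbon rings such as cyclohexyl or cycloheptyl would stay equally flat also remains open.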